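Moving the methyl on the distal ring of the biaryl amide

The source may report more compounds than this note shows. Statements on the series, on what has been measured and on what is new or still open speak of the compounds shown alone.

Three compounds of the series share one core. Compound 1 `COc1ccccc1N1CCN(CCCCC(=O)NCc2ccccc2-c2ccccc2F)CC1` gives 36.5 nM in an assay on CHO-K1 cells for displacement of a labelled ligand from 5-hydroxytryptamine receptor 7 (Homo sapiens), read by scintillation counting (on this read-out lower numbers stand for stronger inhibition and higher numbers for weaker inhibition), compound 2 `COc1ccccc1N1CCN(CCCCC(=O)NCc2ccccc2-c2ccccc2)CC1` gives 37.9 nM, and compound 3 `COc1ccccc1N1CCN(CCCCC(=O)NCc2ccccc2-c2cccc(C)c2)CC1` gives 47.6 nM, all three lying within the scatter of one another: a 1.0-fold higher number from compound 1 to compound 2 (0.02 log units; within the scatter) and a 1.3-fold higher number from compound 2 to compound 3 (0.10 log units; within the scatter) are both small, as is a 1.3-fold higher number from compound 1 to compound 3 (0.12 log units; within the scatter). Compound 4 `COc1ccccc1N1CCN(CCCCC(=O)NCc2ccccc2-c2ccc(C)cc2)CC1` differs from compound 3 in one place, (4-methylphenyl in place of 3-methylphenyl on an aromatic carbon). Going by the values given here, no measured step moves a group around this ring; the nearest guide is that adding the methyl, a 1.3-fold higher number from compound 2 to compound 3 (0.10 log units; within the scatter), changed little. No step beyond the scatter is therefore expected, and the estimated change is a 1.1-fold lower number from compound 3 to compound 4 (0.02 log units; within the scatter). Compound 4 is expected at about 45 nM, between 20 nM and 100 nM.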

Compound 4, inhibition constant: 66.1 nM
For compound 4 the middle estimate is 1.5-fold (0.17 log units) below the measured one, within the range that was stated.
By their numbers in this assay, from the lowest: compounds 1, 2, 3 and 4 (each within the scatter of the next).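

Moving the methyl, with 4-methylphenyl in place of 3-methylphenyl, is the first step shown that moves a group around this ring, and it stays within the scatter in this assay (a 1.4-fold higher number from compound 3 to compound 4 (0.14 log units; within the scatter)). The 4-methylphenyl also stays within the scatter of the other two compounds (a 1.7-fold higher number from compound 2 to compound 4 (0.24 log units; within the scatter); a 1.8-fold higher number from compound 1 to compound 4 (0.26 log units; within the scatter)), so these four compounds do not separate the ring variants. Nothing available bears on why these steps are small.

Still open, going by these compounds, is whether a carboxylic acid or an amine in place of the methyl would give a step beyond the scatter.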